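The source may hold more compounds than are shown below. What is called first, only, known or untested is meant among the compounds shown, and "the series" means these compounds.

Working notes on the series. Among the compounds with values here, in a functional assay on KYSE-410 cells (Homo sapiens) for antiproliferative activity, read by MTT assay, with a stated time of 72 h (a higher number here means a weaker inhibitor, a lower number a stronger inhibitor), compound 1 `O=C(Nc1cccc(F)c1)c1cc(=O)[nH]c2cc(Br)ccc12` gives 7300 nM and compound 3 `O=C(Nc1cc(F)cc(F)c1)c1cc(=O)[nH]c2cc(Br)ccc12` gives 11200 nM, the only two numbers available, and they lie within the scatter of each other, as a 1.5-fold higher number from compound 1 to compound 3 (0.19 log units; within the scatter) shows. Compound 2 `O=C(Nc1cccc(C(F)(F)F)c1)c1cc(=O)[nH]c2cc(Br)ccc12` gives > 20000 nM, which is a limit of the assay. Compound 4 `O=C(Nc1cccc(F)c1)c1cc(=O)[nH]c2cc(-c3cccc(F)c3)ccc12` differs from compound 1 by 3-fluorophenyl in place of bromo on an aromatic carbon. Neither measured step, an at least 2.7-fold higher number from compound 1 to compound 2 (0.43 log units; beyond the scatter) nor a 1.5-fold higher number from compound 1 to compound 3 (0.19 log units; within the scatter), touches that carbon, so both bear on it only loosely and this assay offers no direct guide. A modest move to a lower number is tentatively expected, as an estimated 1.8-fold lower number from compound 1 to compound 4 (0.26 log units; within the scatter). The estimate for compound 4 is 4000 nM, with an expected range of 900 nM to 18000 nM.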

Compound 4, half-maximal inhibitory concentration: 10900 nM
For compound 4 the middle estimate is 2.7-fold (0.44 log units) below the measured one; the range from low to high includes it.
By their numbers in this assay, from the lowest: compounds 1, 4 and 3 (each within the scatter of the next). At a limit, above all of these: compound 2.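

In this assay, within the data shown here, the change at this aromatic carbon of the shared core reads as a 1.5-fold higher number from compound 1 to compound 4 (0.17 log units; within the scatter) and gives the first direct reading at this position. Bromo and 3-fluorophenyl, with its added six-membered aromatic ring of 7 heavy atoms, cannot be told apart here, so this carbon carries the larger group with no readable gain or loss. No data shown bear on why this is so.

As far as these compounds go, what an amine, a carboxylic acid or an unsubstituted phenyl at this carbon would give remains open. From the compounds shown here alone, whether the fluoro on the added ring matters also remains open.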